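A Methylsulfanyl Analogue Expected Near the Assay Limit

A few compounds are considered here, and "the series" means these few. Any claim that something is new, unique, unknown or untested is made for them only; others in the source may bear on it.

The set comprises three measured compounds. In a functional assay on HT-29 cells (Homo sapiens) for cytotoxicity, read by MTT assay, with a stated time of 72 h (a lower number here means a stronger inhibitor of growth, a higher number a weaker inhibitor of growth), compound 1 `COc1ccc(CNc2nc([SeH])nc3ccccc23)cc1` reaches only a limit, > 100000 nM. Compound 2 `CSc1nc(NCCCc2ccccc2)c2ccccc2n1` gives 89600 nM in this assay. For compound 3 `CCCCCSc1nc(NCc2ccc([Se]C)cc2)c2ccccc2n1` this assay reports again only a limit, > 100000 nM. Compound 3 therefore stands where most of the set stands: the limit of > 100000 nM in this assay, at which 2 of the 3 values shown sit, describes the position it shares, and only compound 2 gives a finite number at all.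

Compound 4 `CSc1nc(NCc2ccc([Se]C)cc2)c2ccccc2n1` differs from compound 3 by a single change, (hydrogen in place of butyl on a saturated chain carbon bound to a sulfur), that is, hydrogen in place of butyl on a saturated chain carbon bound to a sulfur. Among the measured compounds shown here, no measured pair reports what this change does in this assay. Compound 2 carries the same methylsulfanyl group and sits close to the limit as well, so a step from compound 3 to compound 4 beyond the scatter in either direction is not expected. Compound 4 is estimated at 100000 nM, between 40000 nM and 250000 nM, which means an expected step of a number no higher from compound 3 to compound 4 (the limit leaves the size open), with a real chance that only a limit is reported.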

Compound 4, concentration for total growth inhibition: > 100000 nM
Compound 4: only a limit was reported; the forecaster's own chance of this, stated with the estimate: 60%; the middle value lies on the limit itself.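

Compound 3 and compound 4 both reach only a limit in this assay, so the step between them cannot be read. The compounds shown leave open what pentylsulfanyl to methylsulfanyl does to growth inhibition on the shared core in this assay.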